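Working notes: the step from compound 3 to compound 4

The compounds below may be only part of what the source reports. "The series", "measured", "known", "first", "only" and "open" are said of these compounds alone.

Values so far in a physicochemical assay for lipophilicity, read by HPLC, at pH 7.4 (on this read-out lower numbers stand for lower lipophilicity and higher numbers for higher lipophilicity), are as follows.
- compound 1 `C[C@@H](Oc1cc2oc(=O)n(CCC(=O)O)c2cc1Cl)c1ccc(F)cn1` reads 1.98
- compound 2 `Cc1ccc([C@@H](C)Oc2cc3oc(=O)n(CCC(=O)O)c3cc2Cl)nc1` reads 2.02
- compound 3 `O=C(O)CCn1c(=O)oc2cc(OCc3ccccc3)c(Cl)cc21` reads 2.71

Compound 3 holds the highest number of the three. Its value of 2.71 stands beyond the scatter from the other two. Compound 1 and compound 2 sit close together and well under it, and the gap between them is a number 0.04 log units higher from compound 1 to compound 2 (within the scatter) and no more.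

The next compound to be read is compound 4 `C[C@@H](Oc1cc2oc(=O)n(CCC(=O)O)c2cc1Cl)c1cccnn1` and it departs from compound 3 by a group of 8 heavy atoms (6 carbon, 2 nitrogen; one six-membered aromatic ring with 2 hetero atoms) in place of a group of 7 heavy atoms (7 carbon; one six-membered aromatic ring of carbon only), on an oxygen on an aromatic ring as its one structural difference. Among the measured compounds shown here, no measured step is this same change. For the measured compounds named here, the only measured step is methyl in place of fluoro on an aromatic carbon, and at a number 0.04 log units higher from compound 1 to compound 2 (within the scatter) it offers no direct guide to size. The expected direction therefore rests on the two lower values alone, with compound 1 at 1.98 and compound 2 at 2.02 as the nearest points of reference. The data hold no direct measure of the entering group, so the range is kept wide.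

The expected change is a number 1.26 log units lower from compound 3 to compound 4 (beyond the scatter) in this assay and this would be a fall beyond the scatter. The estimated value for compound 4 is 1.45 with an expected range of 1.05 to 1.85 as a working figure.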

Compound 4, distribution coefficient: 0.83
Estimate against measurement, compound 4: 0.62 log units above; the whole stated range lies above it.
By their numbers in this assay, from the lowest: compound 4; then compounds 1 and 2 (each within the scatter of the next); then compound 3.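

The earlier compounds shown here showed this part of the molecule only through the swap of methyl for fluoro, at a number 0.04 log units higher from compound 1 to compound 2 (within the scatter) in this assay, whereas replacing the benzyl on an oxygen on an aromatic ring with the pyridazin-3-yl-bearing group gives a number 1.88 log units lower from compound 3 to compound 4 (beyond the scatter) on the same read-out. The two steps that keep the saturated chain carbon and change only the ring on it are also large, with a number 1.19 log units lower from compound 2 to compound 4 (beyond the scatter) for pyridazin-3-yl in place of 5-methylpyridin-2-yl and a number 1.15 log units lower from compound 1 to compound 4 (beyond the scatter) for pyridazin-3-yl in place of 5-fluoropyridin-2-yl, so a large fall appears against all three earlier compounds, and the ring swap alone is enough to produce one. No measurement on hand bears on why the read-out moves this far, and the steps are recorded here without a cause.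

The compounds shown leave open how much of the step from the benzyl compound belongs to the ring and how much to the defined stereocentre, a question that 1-phenylethyl on the same oxygen would address. They also leave open where pyridin-2-yl without a substituent, pyrimidin-2-yl or pyrazin-2-yl would read on that saturated chain carbon.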